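Phenyl group exchange: from compound 2 to compound 3

The source may report more compounds than this note shows. Statements on the series, on what has been measured and on what is new or still open speak of the compounds shown alone.

Measured in a functional assay (muscle tissue) with Cavia porcellus as the target; a lower number here means that less compound is needed, a higher number that more compound is needed for the effect:
- compound 1 `COC(=O)C1=C(C)N=C(C)/C(=C(\O)OC)C1c1ccc(Cl)cc1` gives 8130 nM
- compound 2 `COC(=O)C1=C(C)N=C(C)/C(=C(\O)OC)C1c1cccc(Br)c1` gives 1.29 nM

Of these two numbers, compound 2 at 1.29 nM holds the lower, well beyond the scatter of compound 1. The next structure is compound 3 `COC(=O)C1=C(C)N=C(C)/C(=C(\O)OC)C1c1ccccc1F`, with 2-fluorophenyl in place of 3-bromophenyl on a saturated ring carbon. Within the data shown here, one measured step bears on this change, a swap of the phenyl group at the same place: a 6300-fold lower number from compound 1 to compound 2 (3.80 log units; beyond the scatter). That step is large, so a swap here can matter greatly in this assay. Neither measured compound carries the 2-fluorophenyl group, however, and the size of the step cannot be carried over directly. A moderate rise, smaller than that step, seems likely from the low number of compound 2. The expected change is a 23-fold higher number from compound 2 to compound 3 (1.37 log units; beyond the scatter). For compound 3 the estimated value is 30 nM, with an expected range of 3 nM to 300 nM.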

Compound 3, half-maximal effective concentration: 42.7 nM
The estimate for compound 3 lay 1.4-fold (0.15 log units) below the measured number, within the range that was stated.
By their numbers in this assay, from the lowest: compound 2; then compound 3; then compound 1.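

In this assay, the 2-fluorophenyl group gives an intermediate result, with a 33-fold higher number from compound 2 to compound 3 (1.52 log units; beyond the scatter) and a 190-fold lower number from compound 1 to compound 3 (2.28 log units; beyond the scatter). A phenyl swap on this saturated ring carbon therefore need not produce only the two extremes seen with compound 1 and compound 2, and all three steps are large. The 3-bromophenyl, 2-fluorophenyl and 4-chlorophenyl groups differ in both the halogen and the numbered ring position, and no evidence here gives a cause for the differences.

The effects of halogen identity and ring position therefore remain inseparable, as no pair of compounds shown keeps one fixed while changing the other. Also open, on these data alone, is how an unsubstituted phenyl group, or a phenyl group carrying a methoxy group or a nitro group, would compare at this position.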